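Replacing the group on the aromatic nitrogen of compound 2

This account rests on a few compounds, and the source may have more. Where it says the series, first, only, none or still open, it means among the compounds named here.

- compound 1 `CCNC(=O)Nc1nc2cc(-c3cccnc3)c(=O)n(C(C)C)c2s1`: 42000 nM
- compound 2 `CCNC(=O)Nc1nc2cc(-c3cccnc3)c(=O)n(CC3CCOCC3)c2s1`: 25000 nM

Both values come from a physicochemical assay for solubility, in phosphate buffer, at pH 7.4 (on this read-out lower numbers stand for lower solubility and higher numbers for higher solubility), and compound 2 stands within the scatter of compound 1. Next is compound 3 `CCNC(=O)Nc1nc2cc(-c3cccnc3)c(=O)n(C(C)C(=O)O)c2s1`, with this change: 1-carboxyethyl in place of (oxan-4-yl)methyl on an aromatic nitrogen. Among the measured compounds shown here, the one measured step that bears on it, a 1.7-fold lower number from compound 1 to compound 2 (0.23 log units; within the scatter), also exchanges the group on the aromatic nitrogen, but no measured compound carries 1-carboxyethyl. That step sets no direction, so the expectation rests on the structural change alone. A higher number is expected, as a 3.2-fold higher number from compound 2 to compound 3 (0.51 log units; beyond the scatter). Compound 3 is estimated at 80000 nM, within a range of 30000 nM to 200000 nM.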

Compound 3, solubility: 7290000 nM
The estimate for compound 3 lay 91-fold (1.96 log units) below the measured number; the measured number lies above the stated range.
By their numbers in this assay, from the lowest: compounds 2 and 1 (each within the scatter of the next); then compound 3.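

In this assay the aromatic nitrogen position now shows a large step, where the earlier exchange stayed within the scatter: a 290-fold higher number from compound 2 to compound 3 (2.46 log units; beyond the scatter) with 1-carboxyethyl in place of (oxan-4-yl)methyl, and a 170-fold higher number from compound 1 to compound 3 (2.24 log units; beyond the scatter) with carboxy in place of methyl on the saturated chain carbon. Of the three compounds, only compound 3 carries carboxy. Nothing available accounts for the size of these steps. On these data alone, whether a methyl ester, an amide or an amine on the same chain gives a comparable number stays open, as does the effect of a longer chain ending in a carboxylic acid.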